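The source may report more compounds than this note shows. Statements on the series, on what has been measured and on what is new or still open speak of the compounds shown alone.

In an assay on isolated protein for inhibition of Amine oxidase [flavin-containing] B (Homo sapiens), read by fluorescence and Amplex Red, with a stated time of 30 min, tested at 1 mM (on this read-out lower numbers stand for a weaker effect and higher numbers for a stronger effect at the one concentration tested), compound 1 `CCCCNc1nnc(SCC(=O)N(Cc2cccc([N+](=O)[O-])c2)c2ccc(F)cc2)s1` gives 40.6%, and compound 2 `CC(C)Nc1nnc(SCC(=O)N(Cc2cccc([N+](=O)[O-])c2)c2ccc(F)cc2)s1` gives 36%. Within the data shown here, the only step measured so far, a number 4.6 percentage points lower from compound 1 to compound 2 (within the scatter), is isopropyl in place of butyl on a nitrogen on an aromatic ring. On these two numbers compound 2 lies within the scatter of compound 1, so the two cannot be told apart. Compound 3 `CCNc1nnc(SCC(=O)N(Cc2cccc([N+](=O)[O-])c2)c2ccc(F)cc2)s1` differs from compound 2 by hydrogen in place of methyl on a saturated chain carbon bound to a nitrogen on an aromatic ring and a saturated chain carbon, which read one bond further out is isopropylamino to ethylamino. Among the measured compounds shown here, the one measured step that bears on this, a number 4.6 percentage points lower from compound 1 to compound 2 (within the scatter), also altered the alkyl on that nitrogen and stayed within the scatter, so the further trimming to ethyl is expected to give a number 2 percentage points lower from compound 2 to compound 3 (within the scatter) in this assay, no step beyond the scatter in either direction. Compound 3 is therefore estimated at 34%, with a range from 20% to 48%.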

Compound 3, a percentage reported as inhibition, at one concentration (the size of the read-out at that concentration, not a potency): 41.3%
The estimate for compound 3 lay 7.3 percentage points below the measured number; low and high end bracket the measured number.
By their numbers in this assay, from the lowest: compounds 2, 1 and 3 (each within the scatter of the next).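

In this assay, isopropylamino to ethylamino gives a number 5.3 percentage points higher from compound 2 to compound 3 (within the scatter), and hydrogen in place of ethyl on the saturated chain gives a number 0.7 percentage points higher from compound 1 to compound 3 (within the scatter). Neither step leaves the scatter, so the butyl, isopropyl and ethyl groups on this nitrogen cannot be told apart, and this now holds across three alkyl groups, straight and branched, rather than a single pair. No independent measurement is available to account for this lack of separation.

The compounds shown leave open whether a larger change on this nitrogen, such as a phenyl ring, a cyclohexyl ring or a chain ending in a carboxylic acid, would move the number beyond the scatter. They also leave open whether the plain amine, with no alkyl group on the nitrogen, would read the same.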